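Cyclohexyl in Place of tert-Butyl on the Amine

The compounds below may be only part of what the source reports. "The series", "measured", "known", "first", "only" and "open" are said of these compounds alone.

compound 1 `C=C[C@]1(C)CC[C@@H](C(=C)CNC(C)(C)C)C[C@H]1C(=C)C` — 25400 nM
compound 2 `C=C[C@]1(C)CC[C@@H](C(=C)COCC)C[C@H]1C(=C)C` — 106000 nM

In a functional assay on HeLa cells (Homo sapiens) for antiproliferative activity, read by WST assay, with a stated time of 24 h (a higher number here means a weaker inhibitor, a lower number a stronger inhibitor), compound 1 gives 25400 nM, the lower of the two numbers measured. Compound 2 gives 106000 nM. Among the compounds with values here, the one measured step, a 4.2-fold higher number from compound 1 to compound 2 (0.62 log units; beyond the scatter), replaces the amine itself with an ether and is modest. Compound 3 `C=C[C@]1(C)CC[C@@H](C(=C)CNC2CCCCC2)C[C@H]1C(=C)C` keeps the amine and differs from compound 1 by cyclohexyl in place of tert-butyl on an amine nitrogen. Within the data shown here, no measured step alters the group on the amine nitrogen, so the ether step bears on it only indirectly. The number for compound 3 is therefore expected to stay near that of compound 1, the estimated step being a 1.3-fold lower number from compound 1 to compound 3 (0.10 log units; within the scatter), within the scatter. Compound 3 is estimated at 20000 nM, with a range from 8000 nM to 50000 nM.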

Compound 3, half-maximal inhibitory concentration: 3390 nM
For compound 3 the middle estimate is 5.9-fold (0.77 log units) above the measured one; measured number outside the range, below it.
By their numbers in this assay, from the lowest: compound 3; then compound 1; then compound 2.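

In this assay, the group on the amine nitrogen proves to matter: cyclohexyl in place of tert-butyl gives (a 7.5-fold lower number from compound 1 to compound 3 (0.87 log units; beyond the scatter)), so this position moves the number even though the nitrogen and its chain stay the same. Cyclohexylamino in place of ethoxy gives the large step of the set (a 31-fold lower number from compound 2 to compound 3 (1.50 log units; beyond the scatter)). Nothing measured explains either step.

The compounds shown leave open whether the ring or the extra carbons count here, which a cyclopentyl ring or a straight hexyl chain on the nitrogen would test.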